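Chloro for hydrogen on the thiosemicarbazone aniline ring

The compounds below may be only part of what the source reports. "The series", "measured", "known", "first", "only" and "open" are said of these compounds alone.

Measured compounds:
compound 1, `S=C(N/N=C/c1cccs1)Nc1ccccc1`: 50400 nM
compound 2, `S=C(N/N=C/c1cccs1)Nc1cccc2ccccc12`: 15200 nM

Both compounds were tested in a functional assay on 786-0 cells (Homo sapiens) for inhibition, read by sulforhodamine B assay, with a stated time of 48 h; on this read-out lower numbers stand for stronger inhibition of growth and higher numbers for weaker inhibition of growth. Compound 1 gives the higher of the two numbers, so the weaker growth inhibition; compound 2 gives a number lower by a margin that lies beyond the usual scatter of repeated measurements.

Compound 3, `S=C(N/N=C/c1cccs1)Nc1ccc(Cl)cc1`, is not yet measured. It differs from compound 1 in one place: chloro in place of hydrogen on an aromatic carbon. For the measured compounds named here, no measured pair shows this exact change, so its size can only be guessed from the two compounds above, which show that a larger aromatic group at this position is tolerated and lowers the number.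

For compound 3, a step of a 1.7-fold lower number from compound 1 to compound 3 (0.23 log units; within the scatter) is expected, a modest lowering that may not exceed the scatter. The estimated value for compound 3 is 30000 nM, with a likely range from 10000 nM to 90000 nM.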

Compound 3, concentration for 50% growth inhibition: 7400 nM
For compound 3 the middle estimate is 4.1-fold (0.61 log units) above the measured one; measured number outside the range, below it.
By their numbers in this assay, from the lowest: compound 3; then compound 2; then compound 1.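

In this assay the swap of one hydrogen for chloro, on the six-membered aromatic ring and para to a large group, gives a 6.8-fold lower number from compound 1 to compound 3 (0.83 log units; beyond the scatter) and so stronger inhibition of growth. For the compounds shown here, the earlier compounds showed only that the whole aromatic group could be exchanged for a larger one; this result shows that one added heavy atom at a single place on that ring can also move the number beyond the usual scatter. No measurement available here explains why the chloro group has this effect.

On these data alone, it remains open whether the gain belongs to chloro itself or would also appear with fluoro, methoxy, an amine or a carboxylic acid at this place. Equally open, as far as these compounds go, is how chloro would behave at another place on the same ring.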